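The compounds below may be only part of what the source reports. "The series", "measured", "known", "first", "only" and "open" are said of these compounds alone.

Compound 3 `Cc1nc(N)sc1CCCNC(=N)NC(=O)C[C@H](C)c1ccccc1` gives the lowest number of the three measured compounds in a functional assay on cardiac atrium for agonist activity at histamine H2 receptor (Cavia porcellus) (on this read-out lower numbers stand for an effect already at smaller amounts and higher numbers for an effect only at larger amounts of compound), with 39.8 nM. Compound 1 `Cc1nc(N)sc1CCCNC(=N)NC(=O)C[C@H](C)C1CCCCC1` gives 91.2 nM, and compound 2 `C[C@H](CC(=O)NC(=N)NCCCc1c[nH]cn1)c1ccccc1` gives 93.3 nM. Within the data shown here, the only single change measured so far is a 2.3-fold lower number from compound 1 to compound 3 (0.36 log units; beyond the scatter), a modest step that concerns the aromatic group at the far end of the chain, not the ring bound to the amine side.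

Compound 4 `C[C@@H](CC(=O)NC(=N)NCCCc1c[nH]cn1)c1ccccc1` differs from compound 3 by 1H-imidazol-4-yl in place of 2-amino-4-methyl-1,3-thiazol-5-yl on a saturated chain carbon, three bonds along the chain from an amine nitrogen. Among the measured compounds shown here, no measured pair shows this ring swap on its own; compound 2 carries the same imidazole but with the opposite configuration at the branching carbon, and its value together with that of compound 3 shows the imidazole compound giving the higher of the two numbers. On this basis a small rise is expected in this assay, with a 1.8-fold higher number from compound 3 to compound 4 (0.25 log units; within the scatter), and compound 4 is estimated at 70 nM, between 25 nM and 200 nM.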

Compound 4, half-maximal effective concentration: 25.1 nM
Compound 4: middle estimate off by 2.8-fold (0.45 log units), on the high side, within the range that was stated.
By their numbers in this assay, from the lowest: compounds 4 and 3 (each within the scatter of the next); then compounds 1 and 2 (each within the scatter of the next).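

The swap of 2-amino-4-methyl-1,3-thiazol-5-yl for 1H-imidazol-4-yl, now read on its own, gives a 1.6-fold lower number from compound 3 to compound 4 (0.20 log units; within the scatter) and so does not tell the two rings apart in this assay at this position. Among these compounds, the stereocentre at the saturated chain carbon is a different matter, with a 3.7-fold lower number from compound 2 to compound 4 (0.57 log units; beyond the scatter) as the first step in this set that concerns configuration and not a ring or other group. That step carries one reservation as a reading of configuration alone: the fact that one of compounds 2 and 4 is drawn with a defined configuration and the other without, at the place where they differ.

From the compounds shown here alone, whether the opposite configuration at that carbon gives a similar step with 2-amino-4-methyl-1,3-thiazol-5-yl stays open. So does the effect of a longer chain at the place where the ring is attached, or of a pyridine ring in place of either of these two rings.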